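From fluoro to methyl on a shared core

This account rests on a few compounds, and the source may have more. Where it says the series, first, only, none or still open, it means among the compounds named here.

Of the compounds shown here, three of one shared core have been measured in an ADME assay, in phosphate buffer, with a stated time of 30 min, tested at 1 mM, at a dose of 1 mM, in the presence of a further agent that is not named here; a higher number here means more compound in the circulation at the dose given, a lower number less compound in the circulation. Compound 1 `COc1ccc(-n2sc(=O)n(C3CCCCC3)c2=O)cc1` gives 36300 nM. Going by the values given here, compound 3 `COc1ccc(-n2sc(=O)n(-c3ccc(Cl)cc3)c2=O)cc1` gives 35700 nM, and the only step between measured compounds differing in one place, 4-chlorophenyl in place of cyclohexyl on an aromatic nitrogen, shows a 1.0-fold lower number from compound 1 to compound 3 (0.01 log units; within the scatter). Compound 2 `O=c1sn(-c2ccc(F)cc2)c(=O)n1-c1ccccc1` gives 13400 nM, the lowest of the three numbers, with both compound 1 and compound 3 standing beyond the scatter above it.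

Compound 4 `Cc1ccc(-n2sc(=O)n(-c3ccccc3)c2=O)cc1` is not yet measured. It differs from compound 2 in one place: methyl in place of fluoro on an aromatic carbon. Among the compounds with values here, no measured step bears on this change; the step from compound 1 to compound 3 concerns a different position and was within the scatter, so it gives no guide to the size or direction of the change here. With nothing in the measured compounds to suggest a move, compound 2 is taken as the anchor, and compound 4 is expected to lie close to it, with the expected step of a 1.1-fold higher number from compound 2 to compound 4 (0.05 log units; within the scatter) falling within the scatter. In this assay compound 4 is therefore estimated at 15000 nM, with a range from 7000 nM to 32000 nM.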

Compound 4, maximal plasma concentration: 19400 nM
Beside the measured number, compound 4's estimate is 1.3-fold (0.11 log units) below it; the range from low to high includes it.
By their numbers in this assay, from the lowest: compounds 2, 4, 3 and 1 (each within the scatter of the next, the first and the last beyond it).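

In this assay the step at this place, an aromatic carbon para to a large group, is a 1.4-fold higher number from compound 2 to compound 4 (0.16 log units; within the scatter) and so stays within the scatter, which means that methyl in place of fluoro does not separate these two compounds. Going by these compounds alone, the only earlier step, a 1.0-fold lower number from compound 1 to compound 3 (0.01 log units; within the scatter), concerned a group on an aromatic nitrogen, so this is the first reading at an aromatic carbon, and here too the change stays within the scatter. No supporting measurement bears on why these two compounds lie so close.

On these data alone, whether an amine or a carboxylic acid at this place would move the number beyond the scatter remains open. Also open, as far as these compounds go, is whether methyl in place of fluoro would read the same with cyclohexyl on the aromatic nitrogen.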